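A few compounds are considered here, and "the series" means these few. Any claim that something is new, unique, unknown or untested is made for them only; others in the source may bear on it.

Of the compounds shown here, two from this series have been tested, and a third awaits its number. Compound 1 `O=[N+]([O-])c1ccc(-c2nc3sc(Cc4ccc(Cl)cc4)nn3c2Br)cc1` is one of them, compound 2 `N#CSc1c(-c2ccc(Br)cc2)nc2sc(Cc3ccc(Cl)cc3)nn12` the other; compound 3 `N#CSc1c(-c2ccc([N+](=O)[O-])cc2)nc2sc(Cc3ccc(Cl)cc3)nn12` is the one still to be measured. In an ADME assay on CCRF-CEM cells (Homo sapiens) for cytotoxicity, with a stated time of 72 h (on this read-out lower numbers stand for stronger inhibition and higher numbers for weaker inhibition), compound 1 gives 73000 nM. In this assay compound 2 gives 61000 nM, the lowest of the two numbers, with compound 1 so close that the gap falls within the usual scatter of repeated measurements, so no order between them can be claimed.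

Compound 3 differs from compound 2 in a single place: nitro in place of bromo on an aromatic carbon, in words nitro in place of bromo on an aromatic carbon. Among the measured compounds shown here, no measured pair shows this exact change, so there is no step to lean on. Both measured compounds sit within the scatter of each other, and the expected step of a 1.1-fold higher number from compound 2 to compound 3 (0.03 log units; within the scatter) is none beyond the scatter. Compound 3 is therefore estimated at 65000 nM, likely between 30000 nM and 140000 nM.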

Compound 3, half-maximal inhibitory concentration: 20000 nM
The estimate for compound 3 lay 3.3-fold (0.51 log units) above the measured number; the whole stated range lies above it.
By their numbers in this assay, from the lowest: compound 3; then compounds 2 and 1 (each within the scatter of the next).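

In this assay, 4-nitrophenyl in place of 4-bromophenyl, with the cyanosulfanyl group kept, gives a 3.1-fold lower number from compound 2 to compound 3 (0.48 log units; beyond the scatter) and so shows that the group on this six-membered aromatic ring can shift the read-out beyond the scatter. Keeping the nitro group and placing cyanosulfanyl where bromo stood gives a 3.7-fold lower number from compound 1 to compound 3 (0.56 log units; beyond the scatter) in the same assay, so that second place matters as well, and compound 3 alone carries both the nitro and the cyanosulfanyl groups. No accompanying measurement gives a reason for either step.

From the compounds shown here alone, whether an amine or a carboxylic acid on the same aromatic carbon would lower the number further, or raise it, remains open. Also open, going by these compounds, is whether either step would keep its size with another group in the other place, such as a methyl group.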